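Chloro for hydrogen on the core of compound 1

This account rests on a few compounds, and the source may have more. Where it says the series, first, only, none or still open, it means among the compounds named here.

Compound 1 `ClCc1ccc(Cn2cnc3c(Cl)ncnc32)cc1` gives 2880 nM in a functional assay on SF-268 cells (Homo sapiens) for cytotoxicity, read by sulforhodamine B assay, with a stated time of 48 h (on this read-out lower numbers stand for stronger inhibition of growth and higher numbers for weaker inhibition of growth), the lowest of the three numbers recorded in this series. Compound 2 `ClCc1cccc(Cn2cnc3c(Cl)nc(Cl)nc32)c1` gives 6600 nM in this assay, a higher number than compound 1 by a margin beyond the scatter, and compound 3 `ClCc1ccccc1Cn1cnc2nc(Cl)nc(Cl)c21` gives 24500 nM, higher again and furthest from compound 1. Among the measured compounds shown here, none of the three measured compounds differ in one place only, so no single-change step is available as a guide.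

Compound 4 `ClCc1ccc(Cn2cnc3c(Cl)nc(Cl)nc32)cc1` is compound 1 with one change: chloro in place of hydrogen on an aromatic carbon. Compounds 2 and 3 carry the same dichloro core, but their values cannot be separated from the effect of this change because the chloromethylbenzyl arm also differs between them and compound 1.

For compound 4 the step of a 1.4-fold higher number from compound 1 to compound 4 (0.14 log units; within the scatter) is expected to be small, with the number leaning toward a modest increase rather than a decrease. Compound 4 is therefore estimated at 4000 nM in this assay, within a range of 1500 nM to 12000 nM.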

Compound 4, concentration for total growth inhibition: 5370 nM
The estimate for compound 4 lay 1.3-fold (0.13 log units) below the measured number; the range from low to high includes it.
By their numbers in this assay, from the lowest: compounds 1, 4 and 2 (each within the scatter of the next, the first and the last beyond it); then compound 3.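

The series now has a single-change step: chloro in place of hydrogen on an aromatic carbon, between two ring nitrogen atoms, gives a 1.9-fold higher number from compound 1 to compound 4 (0.27 log units; within the scatter) in this assay. This position of the shared core therefore accepts a chloro group with no shift in growth inhibition that can be told from the scatter, a reading that compounds 2 and 3 could not give. No measurement shown bears on why the number holds.

As far as these compounds go, whether this tolerance extends beyond chloro remains open, for example to an amine, a methoxy group or a longer chain at the same position. Also open, from the compounds shown here alone, is whether the same swap would leave the number unchanged with the chloromethyl group placed elsewhere on the benzyl arm.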